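The compounds below may be only part of what the source reports. "The series", "measured", "known", "first", "only" and "open" are said of these compounds alone.

Measured compounds:
Compound 1, `CCCCCCCCCCc1cn(C(c2ccc(C#N)cc2)c2ccc(C#N)cc2)nn1`, gives 16000 nM in an assay on isolated protein for inhibition of Aromatase (Homo sapiens), read by fluorescence and colorimetric assay, with a stated time of 30 min; on this read-out lower numbers stand for stronger inhibition and higher numbers for weaker inhibition.
Compound 2, `N#Cc1ccc(C(c2ccc(C#N)cc2)n2cc(C3CCCCC3)nn2)cc1`, gives 19300 nM in this assay.

Compound 2 and compound 1 sit within the usual scatter of each other: the step of a 1.2-fold higher number from compound 1 to compound 2 (0.08 log units; within the scatter) is too small to count as a real difference. Compound 3, `N#Cc1ccc(C(c2ccc(C#N)cc2)n2cc(COc3ccccc3)nn2)cc1`, is not yet measured. It differs from compound 2 in one place: phenoxymethyl in place of cyclohexyl on an aromatic carbon. Going by the values given here, the only step measured so far that bears on this change is the one in which the group on that same aromatic carbon was swapped, the step of a 1.2-fold higher number from compound 1 to compound 2 (0.08 log units; within the scatter), and it stayed within the scatter. With nothing else to go on, no step beyond the scatter is expected in this assay in either direction, so compound 3 is estimated at 16000 nM, with a range from 5000 nM to 50000 nM, which means an expected step of a 1.2-fold lower number from compound 2 to compound 3 (0.08 log units; within the scatter).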

Compound 3, half-maximal inhibitory concentration: 11000 nM
For compound 3 the middle estimate is 1.5-fold (0.16 log units) above the measured one; low and high end bracket the measured number.
By their numbers in this assay, from the lowest: compounds 3, 1 and 2 (each within the scatter of the next).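

In this assay, this carbon of the five-membered aromatic ring has now carried three quite different groups without a step beyond the scatter. Replacing the saturated ring of compound 2 with phenoxymethyl, which brings an aromatic ring and an oxygen, gives a 1.8-fold lower number from compound 2 to compound 3 (0.24 log units; within the scatter) as the result, and the comparison with the straight chain of compound 1 gives a 1.5-fold lower number from compound 1 to compound 3 (0.16 log units; within the scatter) as the result, so across these compounds neither the ring type nor the added oxygen shifts the number by a real amount. Nothing measured here speaks to why the numbers lie so close together.

Still open, on these data alone, is what an amine or a carboxylic acid on this carbon would do, and whether a small methyl would leave the number in the same range. Also open, as far as these compounds go, is whether changing the nitrile groups on the shared core would move the number further than any change at this position has.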